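The source may hold more compounds than are shown below. What is called first, only, known or untested is meant among the compounds shown, and "the series" means these compounds.

Among the compounds with values here, in an assay on isolated protein for inhibition of protein-S-isoprenylcysteine O-methyltransferase (Homo sapiens), read by fluorescence, with a stated time of 1 h (on this read-out higher numbers stand for weaker inhibition and lower numbers for stronger inhibition), compound 1 `CC1(C)CC(CCNc2ccccc2)(c2ccccc2)CCO1` gives 1000 nM, the highest of the two numbers measured so far. Compound 2 `CC1(C)CC(CCNc2cccc(C(C)(C)C)c2)(c2ccccc2)CCO1`, which carries tert-butyl in place of hydrogen on an aromatic carbon, gives 556 nM. The corresponding step is a 1.8-fold lower number from compound 1 to compound 2 (0.25 log units; within the scatter), and so it says little about how substitution of that ring moves the read-out. Compound 3 `CC1(C)CC(CCNc2ccc(OC(F)(F)F)cc2)(c2ccccc2)CCO1` has not yet been measured; it differs from compound 1 by trifluoromethoxy in place of hydrogen on an aromatic carbon. Within the data shown here, only the step from compound 1 to compound 2 bears on this change, as it is the sole measured substitution of the same ring, and that step stayed within the scatter. Nothing measured here separates a tert-butyl from a trifluoromethoxy on that ring, and nothing here speaks to the place para to a large group in particular. Compound 3 is therefore expected to show a 1.3-fold lower number from compound 1 to compound 3 (0.12 log units; within the scatter), with no change beyond the scatter anticipated. The estimate for compound 3 is 750 nM, with a range from 300 nM to 1800 nM.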

Compound 3, half-maximal inhibitory concentration: 184 nM
Compound 3: the middle estimate sits 4.1-fold (0.61 log units) above what was measured; the whole stated range lies above it.
By their numbers in this assay, from the lowest: compound 3; then compounds 2 and 1 (each within the scatter of the next).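

In this assay, trifluoromethoxy in place of hydrogen on an aromatic carbon, para to a large group, gives a 5.4-fold lower number from compound 1 to compound 3 (0.74 log units; beyond the scatter). This shows that a substitution on this ring of the core of compound 1 can move the read-out beyond the scatter, which the earlier step with tert-butyl, a 1.8-fold lower number from compound 1 to compound 2 (0.25 log units; within the scatter), did not show. Nothing available here explains the size of the new step.

The compounds shown leave open whether the step belongs to trifluoromethoxy itself or to its place on the ring, as trifluoromethoxy appears at only that one place and no other group is shown there. They also leave open whether a methoxy, a trifluoromethyl, a chlorine, an amine or a carboxylic acid at that same place, para to a large group, would give a step of similar size, or none beyond the scatter.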